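Carbamate-to-Amide Variation at the Piperidine Nitrogen

The source may hold more compounds than are shown below. What is called first, only, known or untested is meant among the compounds shown, and "the series" means these compounds.

Measured so far:
compound 1, `Cc1nc(S(C)(=O)=O)ccc1Oc1ncnc(OC2CCN(C(=O)OC3CCC3)CC2)c1F`, 13.6 nM
compound 2, `Cc1nc(S(C)(=O)=O)ccc1Oc1ncnc(OC2CCN(C(=O)OC3(C(F)(F)F)COC3)CC2)c1F`, 29.3 nM
compound 3, `Cc1nc(S(C)(=O)=O)ccc1Oc1ncnc(OC2CCN(C(=O)C(C)(F)F)CC2)c1F`, 37 nM

All three share the same core and differ only in the group on the carbonyl carbon attached to the ring nitrogen. In a functional assay on isolated protein for inhibition of Glucose-dependent insulinotropic receptor (Homo sapiens), read by HTRF and cAMP accumulation (a lower number here means that less compound is needed, a higher number that more compound is needed for the effect), compound 1 gives 13.6 nM; the change to compound 2 gave a 2.2-fold higher number from compound 1 to compound 2 (0.33 log units; beyond the scatter), and the change to compound 3 gave a 2.7-fold higher number from compound 1 to compound 3 (0.43 log units; beyond the scatter). Compound 3 has the highest number of the three; the smaller of its two gaps is a 1.3-fold higher number from compound 2 to compound 3 (0.10 log units; within the scatter), and the gap to compound 1 is beyond the scatter.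

Compound 4, `Cc1nc(S(C)(=O)=O)ccc1Oc1ncnc(OC2CCN(C(=O)c3noc(C(C)C)n3)CC2)c1F`, carries 5-isopropyl-1,2,4-oxadiazol-3-yl in place of 1,1-difluoroethyl on a carbonyl carbon. Going by the values given here, no measured step touches an aromatic ring in this place; the steps that bear on it are those among compounds 1, 2 and 3, which all stayed modest, whether the group was cyclic or open, oxygen-linked or bound directly to the carbonyl. On that record a step of at most modest size is expected for compound 4 in this assay, with the direction open, and the estimate for compound 4 is 25 nM (range 8 nM to 80 nM), which means an expected 1.5-fold lower number from compound 3 to compound 4 (0.17 log units; within the scatter).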

Compound 4, half-maximal effective concentration: 21.2 nM
Beside the measured number, compound 4's estimate is 1.2-fold (0.07 log units) above it, and the stated range covers the measured number.
By their numbers in this assay, from the lowest: compounds 1, 4, 2 and 3 (each within the scatter of the next, the first and the last beyond it).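

In this assay, a five-membered aromatic ring with 3 hetero atoms on the carbonyl carbon leaves the number close to all three earlier compounds: the steps of a 1.7-fold lower number from compound 3 to compound 4 (0.24 log units; within the scatter) and a 1.4-fold lower number from compound 2 to compound 4 (0.14 log units; within the scatter) and a 1.6-fold higher number from compound 1 to compound 4 (0.19 log units; within the scatter) all stand within the scatter. Compound 4 is also bound directly to the carbonyl through carbon, as compound 3 is, yet it is not separated from the cyclobutyl carbamate compound 1 by more than the scatter, so the gap between compound 1 and compound 3 cannot be read as a general carbamate-to-amide penalty. Nothing available explains why this position takes such different groups with so little movement in the number.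

Still open, as far as these compounds go, is whether the isopropyl on the oxadiazole contributes anything, which a hydrogen or a tert-butyl at that place on the ring would test. Also open, from the compounds shown here alone, is whether any group on this carbonyl carbon moves the number by more than a modest step, for example a dimethylamino group, a phenyl ring or a chain ending in a carboxylic acid.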